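This account rests on a few compounds, and the source may have more. Where it says the series, first, only, none or still open, it means among the compounds named here.

In a functional assay on MV4-11 cells (Homo sapiens) for cytotoxicity (on this read-out higher numbers stand for weaker inhibition and lower numbers for stronger inhibition), compound 1 (`CC(=O)Nc1ccc(Nc2nc(N)n(-c3ccccn3)n2)cc1`) gives 18 nM and compound 2 (`CC(=O)N1CCC(c2ccc(Nc3nc(N)n(-c4ccccn4)n3)cc2)C1`) gives 1 nM as the lower of the two numbers, which means the stronger inhibition of the pair. The next compound to be read is compound 3 (`CN1CCN(c2ccc(Nc3nc(N)n(-c4ccccn4)n3)cc2)CC1`), with 4-methylpiperazin-1-yl in place of 1-acetylpyrrolidin-3-yl on an aromatic carbon, para to a large group (4-methylpiperazin-1-yl in place of 1-acetylpyrrolidin-3-yl on an aromatic carbon). For the measured compounds named here, only one measured step bears on this change: an 18-fold lower number from compound 1 to compound 2 (1.26 log units; beyond the scatter) with 1-acetylpyrrolidin-3-yl in place of acetamido on an aromatic carbon. That large step shows that the number can move well beyond the scatter with the group at this place. Going by the values given here, it says nothing directly about 4-methylpiperazin-1-yl, and no measured compound carries that group. Among the compounds with values here, compound 2 has the lowest number so far at 1 nM and the only other number is higher, so a moderate move toward a higher number is expected in this assay, smaller than the measured step. The expected move is a 4.0-fold higher number from compound 2 to compound 3 (0.60 log units; beyond the scatter) as an estimate only. The estimated value for compound 3 is 4 nM with an expected range of 1 nM to 20 nM in this read-out.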

Compound 3, half-maximal inhibitory concentration: 2 nM
For compound 3 the middle estimate is 2.0-fold (0.30 log units) above the measured one; the measured number falls inside the stated range.
By their numbers in this assay, from the lowest: compounds 2 and 3 (each within the scatter of the next); then compound 1.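

In this assay, the place on an aromatic carbon, para to a large group, now carries two quite different ring substituents with no separation between them (a 2.0-fold higher number from compound 2 to compound 3 (0.30 log units; within the scatter)). Leaving 1-acetylpyrrolidin-3-yl for 4-methylpiperazin-1-yl swaps a five-membered non-aromatic ring with 1 hetero atom for a six-membered one with 2 hetero atoms and removes the double bond outside aromatic rings, so the read-out does not separate these features in this pair. The gain over acetamido also no longer rests on one group, since 4-methylpiperazin-1-yl likewise stands apart from it beyond the scatter, though more modestly (a 9.0-fold lower number from compound 1 to compound 3 (0.95 log units; beyond the scatter)); no information is available on why either ring group differs from acetamido.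

The three compounds leave open whether the ring itself or some feature shared by the two ring groups accounts for the difference from acetamido, and a piperazine without the methyl group or a morpholine ring at the same place would bear on that. From the compounds shown here alone, how a carboxylic acid or a longer chain on the ring nitrogen would read in this assay also remains open.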